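From 4-methylbenzyl to benzyl on the shared core

This account rests on a few compounds, and the source may have more. Where it says the series, first, only, none or still open, it means among the compounds named here.

In a functional assay on MCF7 cells (Homo sapiens) for inhibition, read by sulforhodamine B assay, with a stated time of 48 h (on this read-out lower numbers stand for stronger inhibition and higher numbers for weaker inhibition), compound 1 (`COc1ccc(C(O)(Cc2ccc(C)cc2)c2cccc3ccccc23)c(OC)c1OC`) gives > 20000 nM as its reading, which is a limit and not a number. Going by the values given here, compound 2 (`COc1ccc(C(c2ccccc2O)c2cccc3ccccc23)c(OC)c1OC`) gives 16600 nM in this assay as the only true number so far.

Compound 3 (`COc1ccc(C(O)(Cc2ccccc2)c2cccc3ccccc23)c(OC)c1OC`) is still unmeasured and departs from compound 1 in one place (hydrogen in place of methyl on an aromatic carbon): hydrogen in place of methyl on an aromatic carbon, para to a large group, which reads as 4-methylbenzyl to benzyl. Among the compounds with values here, no measured pair carries this change, so the expectation leans on compound 1 alone, whose reading of > 20000 nM is only a limit. No step beyond the usual scatter is expected in this assay and no direction is favoured. The estimated step (a number no higher from compound 1 to compound 3 (the limit leaves the size open)) is therefore small, and a second reading at the limit is expected to be about as likely as a number. For compound 3 the estimated value is 20000 nM with an expected range from 9000 nM to 45000 nM on the same read-out.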

Compound 3, half-maximal inhibitory concentration: 10600 nM
Compound 3: middle estimate off by 1.9-fold (0.28 log units), on the high side; low and high end bracket the measured number.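

In this assay compound 3 gives 10600 nM, so the benzyl group yields a true number in this pair, and the position on the aromatic ring, para to a large group, now has one firm reading. Compound 1 gives > 20000 nM, which is a limit and not a number. Hydrogen in place of methyl gives an at least 1.8-fold lower number from compound 1 to compound 3 (0.27 log units; that floor lies within the scatter), and the true size of this step cannot be read, so the methyl group is neither shown to matter beyond the scatter nor shown to be without effect, because one end of the pair is a limit: the limit of > 20000 nM in this assay, at which 1 of the 3 values shown sits.

Going by these compounds, this change is seen in a single pair on the shared core, so whether it carries over to any other compound of the series remains open. Also open, on these data alone, is how other groups at this same place would read, such as a chlorine atom, an amine, a carboxylic acid or a longer chain such as 4-propylbenzyl, and whether any of them would move the number clearly beyond the scatter.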